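Bromo for fluoro on the shared urea core

The source may hold more compounds than are shown below. What is called first, only, known or untested is meant among the compounds shown, and "the series" means these compounds.

Measured compounds:
compound 1 `Cc1cccc(NC(=O)N[C@@H](C)c2ccccc2)c1` 99%
compound 2 `C[C@H](NC(=O)Nc1cccc(F)c1)c1ccccc1` 97%

In an ADME assay on the whole organism with Oryza sativa as the target, tested at 0.1 uM (on this read-out higher numbers stand for a weaker effect at the one concentration tested and lower numbers for a stronger effect), compound 1 gives 99% and compound 2 gives 97%. Going by the values given here, compound 2 is the nearest neighbour of compound 1 on these numbers, and the single measured step, a number 2 percentage points lower from compound 1 to compound 2 (within the scatter), lies within the scatter, so the two values cannot be told apart.

Compound 3 `C[C@H](NC(=O)Nc1cccc(Br)c1)c1ccccc1` is not yet measured. It differs from compound 2 in one place: bromo in place of fluoro on an aromatic carbon.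

Among the compounds with values here, only the step from compound 1 to compound 2 bears on this change, and it was a number 2 percentage points lower from compound 1 to compound 2 (within the scatter). Within the data shown here, no measured pair shows the effect of a bromo group, so the expectation rests on both measured compounds sitting close together in this assay. For compound 3 the expected step is a number 1 percentage points lower from compound 2 to compound 3 (within the scatter), meaning no change beyond the scatter. Compound 3 is therefore estimated to give 96%, with a likely range from 86% to 100%.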

Compound 3, a percentage reported as activity, at one concentration (the size of the read-out at that concentration, not a potency): 100%
Compound 3: the middle estimate sits 4 percentage points below what was measured; the range from low to high includes it.
By their numbers in this assay, from the lowest: compounds 2, 1 and 3 (each within the scatter of the next).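

In this assay, bromo in place of fluoro on this aromatic carbon, meta to a large group, gives a number 3 percentage points higher from compound 2 to compound 3 (within the scatter), and bromo in place of methyl gives a number 1 percentage points higher from compound 1 to compound 3 (within the scatter). Methyl, fluoro and bromo at this position therefore cannot be told apart on this read-out, and the earlier pair alone could not show this for bromo. No accompanying measurement offers an explanation for this lack of separation.

On these data alone, it remains open whether an amine, a carboxylic acid or a longer chain on the same carbon would stand clear of the scatter. It is also unknown whether these three compounds would separate at another concentration, since a single concentration says nothing about potency.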